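Compound 4: a Heteroaryl Amide in a Kinase Inhibitor Series

The source may hold more compounds than are shown below. What is called first, only, known or untested is meant among the compounds shown, and "the series" means these compounds.

Measured compounds:
compound 1 `CCCc1ccc(C(=O)Nc2cccc(NC(=O)COc3ccc4c(=O)ccoc4c3)c2)cc1`: 143 nM
compound 2 `O=C(COc1ccc2c(=O)ccoc2c1)Nc1cccc(NC(=O)c2ccc([N+](=O)[O-])cc2)c1`: 67 nM
compound 3 `COC(=O)c1ccc(C(=O)Nc2cccc(NC(=O)COc3ccc4c(=O)ccoc4c3)c2)cc1`: 72 nM

All three were tested in an assay on isolated protein for inhibition of Rho-associated protein kinase 1 (Homo sapiens), read by scintillation counting, radiometric assay and 33P incorporation, with a stated time of 40 min, in the presence of a further agent that is not named here; a lower number here means a stronger inhibitor, a higher number a weaker inhibitor. Compound 3 gives the second highest number of the three. Its nearest neighbour is compound 2, with a 1.1-fold higher number from compound 2 to compound 3 (0.03 log units; within the scatter), a gap that sits within the scatter. The step of a 2.0-fold lower number from compound 1 to compound 3 (0.30 log units; within the scatter) also lies within the scatter, while a 2.1-fold lower number from compound 1 to compound 2 (0.33 log units; beyond the scatter) just crosses it. The three compounds therefore sit close together, and no ordering among them is secure.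

Compound 4 `CC(C)(C)c1cc(C(=O)Nc2cccc(NC(=O)COc3ccc4c(=O)ccoc4c3)c2)no1` differs from compound 3 in one place: 5-(tert-butyl)-1,2-oxazol-3-yl in place of 4-(methoxycarbonyl)phenyl on a carbonyl carbon. Every measured step changes only a substituent on an aromatic carbon of the same six-membered ring, whereas this change removes that ring altogether and puts a five-membered heteroaromatic group on the carbonyl carbon. For the measured compounds named here, no measured step bears directly on such an exchange, and the measured steps show only that the substituent on the phenyl ring mattered little. The estimate for compound 4 therefore rests on little and is given a wide range: the expected step is a 1.5-fold higher number from compound 3 to compound 4 (0.18 log units; within the scatter), and the expected value for compound 4 in this assay is 110 nM, with a range from 30 nM to 450 nM.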

Compound 4, half-maximal inhibitory concentration: 101 nM
For compound 4 the middle estimate is 1.1-fold (0.04 log units) above the measured one; measured number inside the range.
By their numbers in this assay, from the lowest: compounds 2, 3, 4 and 1 (each within the scatter of the next, the first and the last beyond it).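

In this assay, the carbonyl carbon of the amide is shown to carry a group other than a substituted phenyl ring without any step that leaves the scatter: 5-(tert-butyl)-1,2-oxazol-3-yl gives readings of (a 1.4-fold higher number from compound 3 to compound 4 (0.15 log units; within the scatter)) and (a 1.5-fold higher number from compound 2 to compound 4 (0.18 log units; within the scatter)) and (a 1.4-fold lower number from compound 1 to compound 4 (0.15 log units; within the scatter)). The earlier compounds shown here changed only a substituent on one six-membered ring, whereas this result extends the same closeness of values to the exchange of that whole ring for a five-membered aromatic ring with 2 hetero atoms, although one such exchange is a single example. No independent measurement accounts for this result.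

The compounds shown leave open whether the 1,2-oxazole ring or the tert-butyl group matters more for this value, and whether the closeness would hold with a methyl group, an amine or a carboxylic acid in place of the tert-butyl group. They also leave open how far changes to the rest of the shared core would move the number, since all four compounds keep it unchanged.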